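Tert-butyl for methyl on the aniline ring

The compounds below may be only part of what the source reports. "The series", "measured", "known", "first", "only" and "open" are said of these compounds alone.

Measured compounds:
- compound 1 `COc1ccc(/C=C2/CN(C)/C(=N/c3ccc(C)cc3)S2)cc1`: 65700 nM
- compound 2 `COc1ccc(/C=C2\S/C(=N\c3ccc(C(C)(C)C)cc3)N(C)C2=O)cc1`: 46700 nM
- compound 3 `FC(F)(F)c1cc(/N=C2/NC/C(=C/c3ccccc3)S2)cc(C(F)(F)F)c1`: 32800 nM

Going by the values given here, in an ADME assay on TERT-RPE1 cells (Homo sapiens) for cytotoxicity, read by MTT assay, with a stated time of 72 h (a higher number here means a weaker inhibitor, a lower number a stronger inhibitor), compound 1 gives 65700 nM, the highest of the three numbers, yet its gaps to compound 2 and to compound 3 both lie within the usual scatter, so no compound can be called weaker or stronger than another here. Compound 4 `COc1ccc(/C=C2/CN(C)/C(=N/c3ccc(C(C)(C)C)cc3)S2)cc1` is not yet measured. It differs from compound 1 in one place: tert-butyl in place of methyl on an aromatic carbon. Among the compounds with values here, no measured pair shows this change on a shared core, so its effect is unknown. The expected step of a 1.3-fold lower number from compound 1 to compound 4 (0.12 log units; within the scatter) is small and within the scatter, in either direction or none. Compound 4 is therefore estimated at 50000 nM, in the range 20000 nM to 120000 nM.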

Compound 4, half-maximal inhibitory concentration: 23500 nM
Compound 4: middle estimate off by 2.1-fold (0.33 log units), on the high side; the measured number falls inside the stated range.
By their numbers in this assay, from the lowest: compounds 4, 3, 2 and 1 (each within the scatter of the next, the first and the last beyond it).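

In this assay tert-butyl in place of methyl gives a 2.8-fold lower number from compound 1 to compound 4 (0.45 log units; beyond the scatter) on the shared core, the first single-place change available here and one beyond the scatter. Going by these compounds alone, what sits on this aromatic carbon can therefore move the number, which the earlier compounds, differing from one another in more than one place, could not show. No measurement at hand explains this step.

The compounds shown leave open whether ethyl or isopropyl here would give a number between those of methyl and tert-butyl. They also leave open how an amine at this position would behave.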